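A few compounds are considered here, and "the series" means these few. Any claim that something is new, unique, unknown or untested is made for them only; others in the source may bear on it.

Measured in a functional assay on DU-145 cells (Homo sapiens) for cytotoxicity, read by MTT assay; on this read-out higher numbers stand for weaker inhibition and lower numbers for stronger inhibition:
Compound 1 `CC(=O)OC(C)CO[C@H](CC=C(C)C)C1=CC(=O)c2c(O)ccc(O)c2C1=O` gives 16600 nM.
Compound 2 `CCCC(C)(O)CC(=O)O[C@H](CC=C(C)C)C1=CC(=O)c2c(O)ccc(O)c2C1=O` gives 75000 nM.

Compound 2 stands highest of the two numbers; its nearest neighbour is compound 1, from which the step of a 4.5-fold higher number from compound 1 to compound 2 (0.65 log units; beyond the scatter) is beyond the scatter. Compound 3 `CC(C)=CC[C@@H](OC(=O)c1ccoc1)C1=CC(=O)c2c(O)ccc(O)c2C1=O` differs from compound 2 by furan-3-yl in place of 2-hydroxy-2-methylpentyl on a carbonyl carbon. Going by the values given here, no measured step touches this position: the one known step, a 4.5-fold higher number from compound 1 to compound 2 (0.65 log units; beyond the scatter), concerns the group on an oxygen on a saturated carbon and is only a modest change, so it says little about replacing the acyl group on a carbonyl carbon. With no direct guide, the expectation for compound 3 in this assay is a step near the middle of the two known values, estimated as a 2.5-fold lower number from compound 2 to compound 3 (0.40 log units; beyond the scatter) towards a lower number, with a wide range. Compound 3 is therefore estimated at 30000 nM, between 8000 nM and 120000 nM.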

Compound 3, half-maximal inhibitory concentration: > 100000 nM
Compound 3 ended at the assay's limit (the forecaster's own chance of this, stated with the estimate: 15%); middle value at least 3.3-fold (0.52 log units) away from the limit.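

In this assay compound 3 gives > 100000 nM and this is a limit of the assay, not a number. With furan-3-yl on the carbonyl carbon in place of 2-hydroxy-2-methylpentyl, this position now has a reading with a ring as well as an open chain, and the number does not come down: the step is an at least 1.3-fold higher number from compound 2 to compound 3 (0.12 log units; that floor lies within the scatter) and so this floor alone does not separate the two compounds. Set against 2-acetoxypropyl on the oxygen, the step is an at least 6.0-fold higher number from compound 1 to compound 3 (0.77 log units; beyond the scatter) and so both acyl groups shown stand on the higher side of compound 1.

As far as these compounds go, whether an amine or a carboxylic acid on the acyl chain, or a phenyl ring in place of furan-3-yl, would bring the number nearer to compound 1 stays open. How far compound 3 really lies from compound 2 cannot be read because of this limit: the limit of > 100000 nM in this assay, at which 1 of the 3 values shown sits.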